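Aryl amide series: trifluoromethyl to fluoro on a weak binder

A few compounds are considered here, and "the series" means these few. Any claim that something is new, unique, unknown or untested is made for them only; others in the source may bear on it.

Measured so far:
compound 1 `CC(C)(C)Cn1cc2c(Cl)nc(NC(=O)c3ccc(C(F)(F)F)cc3)nc2n1`: > 100000 nM
compound 2 `CC(C)n1cc2c(Cl)nc(NC(=O)c3ccc(C(F)(F)F)cc3)nc2n1`: 13800 nM

In an assay on CHO cells for displacement of a labelled ligand from adenosine receptor A1 (Homo sapiens), read by scintillation counting, with a stated time of 3 h (a lower number here means a stronger inhibitor, a higher number a weaker inhibitor), compound 1 returns only the assay limit of > 100000 nM in this assay, at which 1 of the 2 values shown sits, and no number. Within the data shown here, compound 2 is the one measured neighbour, and the single step between them, an at least 7.2-fold lower number from compound 1 to compound 2 (0.86 log units; beyond the scatter), concerns the substituent on the aromatic nitrogen and leaves the aryl amide untouched.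

Compound 3 `CC(C)(C)Cn1cc2c(Cl)nc(NC(=O)c3ccc(F)cc3)nc2n1` differs from compound 1 at the amide aryl ring instead: fluoro in place of trifluoromethyl on an aromatic carbon. No measured pair in the set changes that ring, so nothing shown bears directly on this step, and it would be guesswork to expect a shift in this assay beyond the scatter in either direction. With compound 1 sitting at the limit, the working expectation is that compound 3 stays in the same region, with a fair chance that this assay again reports only a limit for it.

Compound 3 is therefore estimated at 100000 nM, with a range from 30000 nM to 300000 nM. The expected step is a number no higher from compound 1 to compound 3 (the limit leaves the size open).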

Compound 3, inhibition constant: 16500 nM
For compound 3 the middle estimate is 6.1-fold (0.78 log units) above the measured one, outside the stated range (below it).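

In this assay, the substituent on the amide aryl ring, para to a large group, proves to be a position that can move the read-out: fluoro in place of trifluoromethyl gives an at least 6.0-fold lower number from compound 1 to compound 3 (0.78 log units; beyond the scatter). Compound 3 keeps the neopentyl on the aromatic nitrogen and still returns a number, so neopentyl does not by itself hold a compound of this series at the assay limit; what compound 2 showed for a change at the nitrogen now has a counterpart at the amide aryl ring. The full size of the step stays unknown because compound 1 carries a limit and not a number: the limit of > 100000 nM in this assay, at which 1 of the 3 values shown sits.

Open is whether the change at the aromatic nitrogen and the change at the amide aryl ring add up when both stand in one molecule, since the compounds shown offer each only on its own. Also open, going by these compounds, is how far this position extends the trend, for instance with methoxy, an amine or a plain hydrogen on the aromatic carbon in place of fluoro.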